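The compounds below may be only part of what the source reports. "The series", "measured", "known", "first", "only" and "open" are said of these compounds alone.

Working notes on the series. The shared core, as in compound 1 `O=C(c1cccc(F)c1)N1CC(c2nc(-c3cccc(Cl)c3)no2)C1`, carries an aromatic ring at one end and an amide at the other. In an assay on HEK293 cells for negative allosteric modulation of metabotropic glutamate receptor 5 (Homo sapiens), read by FLIPR (a higher number here means a weaker inhibitor, a lower number a stronger inhibitor), compound 1 gives 780 nM, the lowest of the two numbers recorded so far. Compound 2 `Cc1cccc(-c2noc(C3CN(C(=O)c4cccc(F)c4)C3)n2)c1` gives 2100 nM in this assay; the step of a 2.7-fold higher number from compound 1 to compound 2 (0.43 log units; beyond the scatter) goes with methyl in place of chloro on an aromatic carbon.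

Compound 3 `O=C(C1CCC(F)(F)CC1)N1CC(c2nc(-c3cccc(F)c3)no2)C1` is the remaining entry; in this assay compound 3 gives > 10000 nM, which is a limit of the assay rather than a number (the limit of > 10000 nM in this assay, at which 1 of the 3 values shown sits). Going by the values given here, compound 3 differs from compound 1 in two places at once, so no single step is recorded between them.

Compound 4 `O=C(C1CCC1)N1CC(c2nc(-c3cccc(Cl)c3)no2)C1` changes the amide side of compound 1: cyclobutyl in place of 3-fluorophenyl on a carbonyl carbon. Among the compounds with values here, the only measured step, a 2.7-fold higher number from compound 1 to compound 2 (0.43 log units; beyond the scatter), sits on the aromatic ring at the far end and does not bear on the carbonyl substituent. Compound 3 also carries a saturated ring on the carbonyl, and its reading is a limit, but its aromatic ring differs too, so its value and that of compound 1 show only that such a pairing can fall off the scale.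

The step expected here is a 3.8-fold higher number from compound 1 to compound 4 (0.59 log units; beyond the scatter), a weakening. Compound 4 is estimated at 3000 nM, with a range from 800 nM to 12000 nM.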

Compound 4, half-maximal inhibitory concentration: 1500 nM
Estimate against measurement, compound 4: 2.0-fold (0.30 log units) above, and the stated range covers the measured number.
By their numbers in this assay, from the lowest: compounds 1, 4 and 2 (each within the scatter of the next, the first and the last beyond it). At a limit, above all of these: compound 3.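

Going by these compounds alone, the step of a 1.9-fold higher number from compound 1 to compound 4 (0.28 log units; within the scatter) is the first single change read at the carbonyl carbon, and in this assay it lies within the scatter. With the rest of compound 1 held fixed, the six-membered aromatic ring of 3-fluorophenyl can therefore give way to the four-membered non-aromatic ring of cyclobutyl, with fewer heavy atoms, and the number stays within the scatter, so an aromatic ring on this carbonyl carbon is not needed to keep the reading of compound 1. Compound 3 also carries a non-aromatic ring on the carbonyl, but its reading is a limit and it differs from compound 4 in two places, so it cannot be set against this step: the limit of > 10000 nM in this assay, at which 1 of the 4 values shown sits.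

Open, as far as these compounds go, is whether the carbonyl carbon accepts other groups equally, such as an open-chain tert-butyl or a piperidine ring carrying a basic amine, and whether the limit of compound 3 goes with its carbonyl substituent or with its other change. Also open, from the compounds shown here alone, is whether the step of a 2.7-fold higher number from compound 1 to compound 2 (0.43 log units; beyond the scatter) repeats when cyclobutyl sits on the carbonyl.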